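Hydrogen for Methyl on the Aromatic Nitrogen: Compound 4

The source may hold more compounds than are shown below. What is called first, only, known or untested is meant among the compounds shown, and "the series" means these compounds.

Working notes on the series.

Of the compounds shown here, three have been measured in a functional assay on MCF7 cells (Homo sapiens) for antiproliferative activity, read by MTT assay, with a stated time of 48 h; a higher number here means a weaker inhibitor, a lower number a stronger inhibitor. Compound 3 `COc1ccc2c(/C=C/C(=O)c3cc(OC)c(OC)c(SC)c3)cn(C)c2c1` gives 166 nM in this assay. Among the compounds with values here, compound 1 `COc1ccc2c(/C=C/C(=O)c3cc(OC)c(OC)c(SC)c3)c[nH]c2c1` differs from compound 3 in one place, (hydrogen in place of methyl on an aromatic nitrogen); in this assay compound 1 gives 101 nM, and the step of a 1.6-fold lower number from compound 3 to compound 1 (0.22 log units; within the scatter) is the only measured instance of this change. Compound 2 `COc1ccc2c(/C=C(\C)C(=O)c3cc(OC)c(OC)c([Se]C)c3)cn(C)c2c1` gives 44 nM in this assay, the lowest number of the three, and its steps to compound 1 and to compound 3 both lie beyond the scatter. The difference between the core of compound 2 and the core of compound 3 is not broken down here.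

Compound 4 `COc1ccc2c(/C=C(\C)C(=O)c3cc(OC)c(OC)c([Se]C)c3)c[nH]c2c1` has not yet been measured. It differs from compound 2 by hydrogen in place of methyl on an aromatic nitrogen, the same change that separates compound 3 from compound 1, on a place described in identical words.

Expectation for compound 4 rests on two things: the value of compound 2, 44 nM, as the starting point, and the single measured step of a 1.6-fold lower number from compound 3 to compound 1 (0.22 log units; within the scatter) as the only guide to the size of the change. The step from compound 2 to compound 4 is expected to be a 1.5-fold lower number from compound 2 to compound 4 (0.17 log units; within the scatter). Compound 4 is estimated at 30 nM in this assay. For compound 4 the range is estimated to run from 12 nM to 75 nM. Within the data shown here, this range is kept wide: the change has only one precedent, the step of a 1.6-fold lower number from compound 3 to compound 1 (0.22 log units; within the scatter), and that on a different core.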

Compound 4, half-maximal inhibitory concentration: 35 nM
Estimate against measurement, compound 4: 1.2-fold (0.07 log units) below, within the range that was stated.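

Hydrogen in place of methyl on the aromatic nitrogen can now be read on two cores in this assay, and the new step is a 1.3-fold lower number from compound 2 to compound 4 (0.10 log units; within the scatter). Set beside the earlier step, the new one does not differ from it: the same change on two cores in this assay, a 1.6-fold lower number (0.22 log units; within the scatter) from compound 3 to compound 1 and a 1.3-fold lower number (0.10 log units; within the scatter) from compound 2 to compound 4, 1.3-fold (0.12 log units) apart, within the scatter of two such steps. The pair shows that the change carries from one core to the other with no detectable difference in size, but each step lies within the scatter on its own, and it therefore does not show that the change moves the number at all, while two cores are too few to support a rule for the series.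

The compounds shown carry only hydrogen or methyl on that nitrogen, leaving open how a longer chain such as propyl, or a chain ending in an amine or a carboxylic acid, would read in this assay. Within the data shown here, the two cores also differ from each other in more than one place, and no pair here separates the selenium-bearing group from the sulfur-bearing group or isolates the extra methyl on the chain linking the two ring systems.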